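The source may hold more compounds than are shown below. What is called first, only, known or untested is meant among the compounds shown, and "the series" means these compounds.

Compound 1 `COc1ccc(/C=C/C(=O)c2ccc(N)c(-c3ccc(F)cc3)c2)cc1O`: 940 nM
Compound 2 `COc1cc(/C=C/C(=O)c2ccc(N)c(-c3ccc(F)cc3)c2)cc(Br)c1O`: > 50000 nM (a limit of the assay)

Within the data shown here, in a functional assay on A549 cells (Homo sapiens) for cytotoxicity, read by sulforhodamine B assay, with a stated time of 48 h (a higher number here means a weaker inhibitor, a lower number a stronger inhibitor), compound 1 gives 940 nM, the only actual number so far. Compound 2 reaches only a limit, > 50000 nM.

Compound 3 `COc1ccc(/C=C/C(=O)c2ccc(N)c(-c3ccc(F)cc3)c2)cc1` has hydrogen in place of hydroxy on an aromatic carbon, ortho to a methoxy group (hydrogen in place of hydroxy on an aromatic carbon). This turns 3-hydroxy-4-methoxyphenyl into 4-methoxyphenyl. Among the measured compounds shown here, no measured pair isolates this change, so the expectation is tentative: a moderate loss of potency, beyond the scatter, starting from compound 1 at 940 nM. The expected step is a 3.2-fold higher number from compound 1 to compound 3 (0.50 log units; beyond the scatter). For compound 3 the estimated value is 3000 nM, with an expected range of 700 nM to 15000 nM.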

Compound 3, half-maximal inhibitory concentration: 4310 nM
Estimate against measurement, compound 3: 1.4-fold (0.16 log units) below; the range from low to high includes it.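

In this assay, hydrogen in place of hydroxy on the aromatic carbon ortho to the methoxy group gives a 4.6-fold higher number from compound 1 to compound 3 (0.66 log units; beyond the scatter). Hydroxy is therefore favoured over hydrogen at this position, although compound 3 still gives a measured number and not a limit of the assay. Nothing shown here accounts for the size of this step.

Going by these compounds, it remains open whether the gain is specific to hydroxy, since an amine or a fluorine on the same carbon would separate hydroxy from other replacements. The role of the methoxy group is also unresolved, with an ethoxy group as one possible comparison.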